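A few compounds are considered here, and "the series" means these few. Any claim that something is new, unique, unknown or untested is made for them only; others in the source may bear on it.

In an ADME assay on RAW264.7 cells (Mus musculus) for cytotoxicity, read by MTT assay, with a stated time of 48 h (a higher number here means that more compound is tolerated, a lower number that less compound is tolerated), compound 1 (`C#CCN(c1nc(-c2cccc(Br)c2)no1)C1CCCCC1`) gives 31.8 ug/mL, level within the scatter with compound 2 (`CC(=O)OC[C@H]1O[C@H](OC[C@H](Cn2cc(COc3ccc(-c4noc(NC5CCCCC5)n4)cc3)nn2)OC(C)=O)C=C[C@@H]1OC(C)=O`) at 33.3 ug/mL. Compound 3 (`CC(=O)OC[C@H]1O[C@H](OC[C@@H](Cn2cc(CN(c3nc(-c4cccc([N+](=O)[O-])c4)no3)C3CCCCC3)nn2)OC(C)=O)C=C[C@@H]1OC(C)=O`) gives 100 ug/mL, beyond the scatter from compound 1. Compound 4 (`C#CCN(c1nc(-c2ccccc2)no1)C1CCCCC1`) differs from compound 1 in one place: hydrogen in place of bromo on an aromatic carbon. Among the compounds with values here, no measured pair isolates this change, so the three values offer no direct guide to it. In this assay, no shift beyond the scatter is expected, with only a slight lean toward more compound being tolerated. The estimated 1.3-fold higher number from compound 1 to compound 4 (0.10 log units; within the scatter) stays within the scatter. For compound 4 the expected value is 40 ug/mL, with an estimated range of 18 ug/mL to 90 ug/mL.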

Compound 4, half-maximal cytotoxic concentration: 32.1 ug/mL
Compound 4: middle estimate off by 1.2-fold (0.10 log units), on the high side; the range from low to high includes it.
By their numbers in this assay, from the lowest: compounds 1, 4 and 2 (each within the scatter of the next); then compound 3.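

In this assay, the change from 3-bromophenyl to phenyl gives a 1.0-fold higher number from compound 1 to compound 4 (0.00 log units; within the scatter), so on this core the bromo group can be replaced by hydrogen with no shift beyond the scatter. This is the only pair shown that isolates a change at this place, on an aromatic carbon of the six-membered ring. Nothing measured here accounts for this flat step. On these data alone, whether an amine or a carboxylic acid at this place would move the number stays open. Also open, as far as these compounds go, is whether the same step holds on a core other than that of compound 1.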